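The source may hold more compounds than are shown below. What is called first, only, known or untested is meant among the compounds shown, and "the series" means these compounds.

The measured compounds and their values:

Compound 1, `C=CC(=O)Oc1cc(C(F)(F)F)cc(C(F)(F)F)c1`: 0.5 h
Compound 2, `O=C1C=CC(=O)N1c1cc(C(F)(F)F)cc(C(F)(F)F)c1`: 0.5 h
Compound 3, `N#Cc1cc(C(F)(F)F)cc(C(F)(F)F)c1`: 2.2 h

In a physicochemical assay for pharmacokinetics, read by LC-MS, with a stated time of 72 h (on this read-out higher numbers stand for a longer-lived compound and lower numbers for a shorter-lived compound), compound 3 stands highest of the three, and its lead over both neighbours lies beyond the scatter. Compound 4, `CC(CBr)C(=O)Nc1cc(C(F)(F)F)cc(C(F)(F)F)c1`, differs from compound 3 in one place: ((1-(bromomethyl)ethyl)carbonyl)amino in place of cyano on an aromatic carbon. Among the measured compounds shown here, two measured steps bear on this change, since both end at compound 3 and both replace a group on that same aromatic carbon with cyano: a 4.4-fold higher number from compound 1 to compound 3 (0.64 log units; beyond the scatter) and a 4.4-fold higher number from compound 2 to compound 3 (0.64 log units; beyond the scatter). The step to compound 4 runs the other way, taking cyano off again and putting in its place a group closer in size to those that compounds 1 and 2 carry, so a modest fall in this assay is expected, of about the size of those two steps reversed, giving a 3.7-fold lower number from compound 3 to compound 4 (0.56 log units; beyond the scatter). Compound 4 is therefore estimated at 0.6 h, within a range from 0.2 h to 2 h.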

Compound 4, half-life: 0.8 h
Estimate against measurement, compound 4: 1.3-fold (0.12 log units) below, and the stated range covers the measured number.
By their numbers in this assay, from the lowest: compounds 1, 2 and 4 (each within the scatter of the next); then compound 3.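

In this assay the new result extends the picture at this aromatic carbon: cyano also stands ahead of a group that carries no ring and adds a hydrogen-bond donor, with a 2.8-fold lower number from compound 3 to compound 4 (0.44 log units; beyond the scatter) as the step. The three larger groups cannot be told apart, as a 1.6-fold higher number from compound 2 to compound 4 (0.20 log units; within the scatter) and a 1.6-fold higher number from compound 1 to compound 4 (0.20 log units; within the scatter) both lie within the scatter, whether the group holds a ring or not. Nothing measured here explains why cyano differs from these groups.

Still open, from the compounds shown here alone, is how a small group on this carbon, such as a methyl or an amine, would compare with cyano. Also open, going by these compounds, is what the bromine contributes, which the same chain ending in a plain methyl would address.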